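The source may report more compounds than this note shows. Statements on the series, on what has been measured and on what is new or still open speak of the compounds shown alone.

Of the compounds shown here, two of a shared core have been measured so far. Compound 1, `C=CCNC(=O)n1c(-c2ccc(OC)cc2)cc(=O)c2c(OC)cc(OC)cc21`, carries an allyl carbamoyl group on the ring nitrogen, and in an ADME assay on BJ cells (Homo sapiens) for antiproliferative activity, with a stated time of 72 h (on this read-out lower numbers stand for an effect already at smaller amounts and higher numbers for an effect only at larger amounts of compound), compound 1 gives 74000 nM. Compound 2, `COc1ccc(-c2cc(=O)c3c(OC)cc(OC)cc3n2S(=O)(=O)c2ccc(C)c([N+](=O)[O-])c2)cc1`, carries instead a sulfonyl group bearing a 4-methyl-3-nitrophenyl on that nitrogen. In this assay compound 2 gives only > 51700 nM, which is a limit of the assay and not a measured number; this is the limit of > 51700 nM in this assay, at which 1 of the 2 values shown sits. So compound 2 stands at the limit, with no exact value known, and compound 1 stands at a number well towards the weak end of the range.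

Compound 3, `COc1ccc(-c2cc(=O)c3c(OC)cc(OC)cc3n2S(=O)(=O)c2ccc(OC)cc2)cc1`, differs from compound 2 in one place: 4-methoxyphenyl in place of 4-methyl-3-nitrophenyl on a sulfonyl sulfur. Going by the values given here, no step between two measured compounds of this kind is available, so there is no measured guide for the size of the change. Since compound 2 sits at the limit, the step from compound 2 to compound 3 is expected to be small or absent, a step that the limit leaves unreadable from compound 2 to compound 3, and compound 3 is expected to give about 60000 nM, somewhere between 20000 nM and 150000 nM, quite possibly again only as a limit.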

Compound 3, half-maximal effective concentration: > 82700 nM
Compound 3 was reported as a limit; the forecaster's own chance of this, stated with the estimate: 65%; middle value at least 1.3-fold (0.13 log units) from the limit.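

In this assay compound 3 gives > 82700 nM, which is a limit of the assay and not a number. Swapping 4-methyl-3-nitrophenyl for 4-methoxyphenyl on the sulfonyl sulfur therefore still gives no exact value, and the step between these two sulfonyl compounds cannot be read: the limit of > 82700 nM in this assay, at which 1 of the 3 values shown sits. The new compound also allows a first comparison of two kinds of group on the aromatic nitrogen, as (4-methoxyphenyl)sulfonyl in place of allylcarbamoyl gives an at least 1.1-fold higher number from compound 1 to compound 3 (0.04 log units; that floor lies within the scatter), so this floor does not establish a real difference between the two groups.

From the compounds shown here alone, how far the true values of compound 2 and compound 3 lie beyond their limits remains open, and so does the order of these two sulfonyl compounds. Also open, going by these compounds, is whether a sulfonyl group carrying a plain methyl, or an aryl group bearing an amine or a carboxylic acid, on the aromatic nitrogen of the shared core would give a value that can be read as a number.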